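A few compounds are considered here, and "the series" means these few. Any claim that something is new, unique, unknown or untested is made for them only; others in the source may bear on it.

Measured compounds in an assay on isolated protein for displacement of a labelled ligand from sphingosine 1-phosphate receptor 4 (Homo sapiens); a lower number here means a stronger inhibitor, a higher number a weaker inhibitor:
- compound 1 `C[C@](N)(COP(=O)(O)O)C(=O)Nc1ccc(Oc2ccc(-c3ccccc3)cc2)cc1` gives 123 nM
- compound 2 `C[C@](N)(COP(=O)(O)O)C(=O)Nc1ccc(OCCc2cccc3ccccc23)cc1` gives "not determined" (no result reported)
- compound 3 `C[C@](N)(COP(=O)(O)O)C(=O)Nc1ccc(OCCc2ccc(-c3cccs3)cc2)cc1` gives "not determined" (no result reported)

Compound 2 stands without a single number in this assay; the entry for compound 3 is likewise without a single number, so only compound 1 gives a value for the series. Compound 4 `C[C@](N)(COP(=O)(O)O)C(=O)Nc1ccc(OCCCCCc2ccccc2)cc1` has not been measured yet. It differs from compound 2 by 3-phenylpropyl in place of naphthalen-1-yl on a saturated chain carbon, two bonds along the chain from an oxygen on an aromatic ring. Within the data shown here, no measured step joins the two compounds, so no size or direction of the step can be drawn from the numbers; anything from no change beyond the scatter to a step in either direction remains open. Compound 4 is expected at 400 nM, within 60 nM to 3000 nM.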

Compound 4, half-maximal inhibitory concentration: 3.6 nM
Compound 4: the middle estimate sits 110-fold (2.05 log units) above what was measured, and the stated range ends above it.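

In this assay, among these compounds, compound 2 carries no single number, so no step to compound 4 can be read. As far as these compounds go, what 3-phenylpropyl in place of naphthalen-1-yl does to the value stays open. No evidence bears on this result.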